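Swapping the amino ester side chain for a carbamate

A few compounds are considered here, and "the series" means these few. Any claim that something is new, unique, unknown or untested is made for them only; others in the source may bear on it.

- Compound 1 `COC(=O)[C@@H](NC(=O)CSc1nc(-c2ccccc2)cc(-c2ccc(C)cc2)c1C#N)C(C)C` value 210000 nM
- Compound 2 `COC(=O)CC[C@H](NC(=O)CSc1nc(-c2ccccc2)cc(-c2ccc(C)cc2)c1C#N)C(=O)OC` value > 250000 nM (a limit)
- Compound 3 `COC(=O)C[C@H](NC(=O)[C@@H](NC(=O)CSc1nc(-c2ccccc2)cc(-c2ccc(C)cc2)c1C#N)C(C)C)C(=O)OC` value > 250000 nM (a limit)

Within the data shown here, in an ADME assay on MDCK cells (Canis lupus familiaris) for cytotoxicity, read by MTT assay, with a stated time of 48 h (a higher number here means that more compound is tolerated, a lower number that less compound is tolerated), compound 1 gives 210000 nM as the only actual number of the three. The two other results stand at the limit of > 250000 nM in this assay, at which 2 of the 3 values shown sit, and are limits, not numbers.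

Compound 4 `Cc1ccc(-c2cc(-c3ccccc3)nc(SCNC(=O)OC(C)(C)C)c2C#N)cc1` carries (tert-butoxycarbonyl)amino in place of (1-(methoxycarbonyl)-2-methylpropyl)carbamoyl on a saturated chain carbon bound to a sulfur, and the full count is (tert-butoxycarbonyl)amino in place of (1-(methoxycarbonyl)-2-methylpropyl)carbamoyl on a saturated chain carbon bound to a sulfur for this change.

Among the measured compounds shown here, two measured steps touch the part that leaves. They are an at least 1.1-fold higher number from compound 1 to compound 2 (0.07 log units; that floor lies within the scatter) and also an at least 1.1-fold higher number from compound 1 to compound 3 (0.07 log units; that floor lies within the scatter) as the second case. Both are floors, and neither shows a change beyond the scatter. No step beyond the scatter is therefore expected in this assay for this replacement. The expected move is a 1.2-fold lower number from compound 1 to compound 4 (0.07 log units; within the scatter) as a working figure. Compound 4 is estimated at 180000 nM with an expected range from 70000 nM to 250000 nM in this assay.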

Compound 4, half-maximal cytotoxic concentration: > 250000 nM
Compound 4 gave a limit, no number; the forecaster's own chance of this, stated with the estimate: 30%; at least 1.3-fold (0.14 log units) between middle value and limit.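

In this assay compound 4 gives > 250000 nM, which is a limit and not a number. The earlier steps shown here altered the amino ester side chain but kept it in place, whereas here (tert-butoxycarbonyl)amino replaces the whole of (1-(methoxycarbonyl)-2-methylpropyl)carbamoyl, defined stereocentre included, and the result is an at least 1.1-fold higher number from compound 1 to compound 4 (0.07 log units; that floor lies within the scatter). So the side chain can leave altogether while the reading still reaches the limit, and compound 2, compound 3 and compound 4 cannot be ordered among themselves: the limit of > 250000 nM in this assay, at which 3 of the 4 values shown sit.

On these data alone, it stays open whether a free amine or a carboxylic acid on this saturated chain carbon bound to a sulfur would bring the reading down to an actual number. The same holds for a longer chain at this place.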